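A few compounds are considered here, and "the series" means these few. Any claim that something is new, unique, unknown or untested is made for them only; others in the source may bear on it.

Measured so far:
- compound 1, `COc1ccc(-c2c(C)nn3c(NCc4cccnc4)nc(C)cc23)cc1OC`, in a physicochemical assay for acid dissociation, gives 2.8
- compound 2, `COc1ccc(-c2c(C)nn3c(NCC4CCOCC4)nc(C)cc23)cc1OC`, in this assay gives 4.4
- compound 3, `COc1ccc(-c2c(C)nn3c(NCc4cccnc4)cc(C)nc23)cc1OC`, in this assay gives 5.4

Compound 1 and compound 2 share the same core and differ in one place: oxan-4-yl in place of pyridin-3-yl on a saturated chain carbon bound to a nitrogen on an aromatic ring. That change made a step of a number 1.60 log units higher from compound 1 to compound 2 (beyond the scatter), a large rise well beyond the scatter. Compound 3 is built from the same atoms as compound 1, joined differently; the difference between the two cores is not broken down here. Compound 3 stands highest of the three, beyond the scatter from compound 2 and from compound 1.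

Compound 4, `COc1ccc(-c2c(C)nn3c(NCC4CCOCC4)cc(C)nc23)cc1OC`, has not yet been measured. It relates to compound 3 exactly as compound 2 relates to compound 1: oxan-4-yl in place of pyridin-3-yl on a saturated chain carbon bound to a nitrogen on an aromatic ring, at the same place in the molecule. Among the measured compounds shown here, the only measured example of this change is the step from compound 1 to compound 2. For the measured compounds named here, on that basis a step of roughly the same direction and size is expected from compound 3 to compound 4, namely a number 1.40 log units higher from compound 3 to compound 4 (beyond the scatter), although the second core is different and a single example gives no guarantee that the step repeats. Compound 4 is therefore estimated at 6.8, likely between 5.8 and 7.8.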

Compound 4, acid dissociation constant: 5.7
For compound 4 the middle estimate is 1.10 log units above the measured one, outside the stated range (below it).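

In this assay the change from pyridin-3-yl to oxan-4-yl gave a step of a number 1.60 log units higher from compound 1 to compound 2 (beyond the scatter) on the core of compound 1 but of a number 0.30 log units higher from compound 3 to compound 4 (within the scatter) on the other core. The same swap at the same place therefore did not carry over in size between these two cores, so a step seen on one core cannot simply be added to a compound on the other in this series. With only these two pairs, this is one mismatch rather than a general rule, and nothing available here explains it.

The compounds shown leave open whether piperidin-4-yl, which carries an amine, or a group with a carboxylic acid would also behave differently on the two cores when placed on a saturated chain carbon bound to a nitrogen on an aromatic ring. They also leave open whether a longer chain carrying pyridin-3-yl or oxan-4-yl would show the same mismatch.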